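The compounds below may be only part of what the source reports. "The series", "measured", "known", "first", "only" and "open" are said of these compounds alone.

Three compounds share one core and differ only in the group on an amine nitrogen in a ring. Compound 1 `O=C(c1nc2cc(C(F)(F)F)ccc2s1)N1CCN(c2cnccn2)CC1` gives 28.1% in an ADME assay on RAW264.7 cells (Mus musculus) for cytotoxicity, read by MTT assay, with a stated time of 72 h, tested at 50 ug/mL; on this read-out lower numbers stand for less inhibition and higher numbers for more inhibition at the one concentration tested (going by the name of the read-out). Compound 2 `CN1CCN(C(=O)c2nc3cc(C(F)(F)F)ccc3s2)CC1` gives 12.6%, and compound 3 `O=C(c1nc2cc(C(F)(F)F)ccc2s1)N1CCN(c2ccncc2)CC1` gives 17.5%. Compound 3 stands second highest of the three; its nearest neighbour is compound 2, with a number 4.9 percentage points higher from compound 2 to compound 3 (within the scatter), while the step of a number 10.6 percentage points lower from compound 1 to compound 3 (beyond the scatter) lies beyond the scatter, as does a number 15.5 percentage points lower from compound 1 to compound 2 (beyond the scatter). Compound 4 `COc1ccc(N2CCN(C(=O)c3nc4cc(C(F)(F)F)ccc4s3)CC2)cc1` carries a change at the same place: 4-methoxyphenyl in place of pyridin-4-yl on an amine nitrogen in a ring. Two earlier exchanges on that nitrogen gave one modest step and one within the scatter, so a change of at most modest size is expected, with no clear direction. Compound 4 is therefore estimated at 20%, between 8% and 35%, a step of a number 2.5 percentage points higher from compound 3 to compound 4 (within the scatter).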

Compound 4, a percentage reported as inhibition, at one concentration (the size of the read-out at that concentration, not a potency): 19.4%
Beside the measured number, compound 4's estimate is 0.6 percentage points above it, within the range that was stated.
By their numbers in this assay, from the lowest: compounds 2, 3, 4 and 1 (each within the scatter of the next, the first and the last beyond it).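

In this assay, 4-methoxyphenyl, with its aromatic ring of carbon only, can replace pyridin-4-yl without a step beyond the scatter (a number 1.9 percentage points higher from compound 3 to compound 4 (within the scatter)). Compound 4 also stays within the scatter of the other two compounds (a number 6.8 percentage points higher from compound 2 to compound 4 (within the scatter); a number 8.7 percentage points lower from compound 1 to compound 4 (within the scatter)), although compound 1 lies beyond the scatter of both compound 2 and compound 3. No supporting measurement accounts for these results.

Still open, as far as these compounds go, is how a carboxylic acid, a primary amine or a longer alkyl chain on this nitrogen would read in this test. From the compounds shown here alone, the effect of changing the shared core also remains open.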